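Working notes: compound 3 to compound 4

The compounds below may be only part of what the source reports. "The series", "measured", "known", "first", "only" and "open" are said of these compounds alone.

Measured in a functional assay on PC-3 cells (Homo sapiens) for antiproliferative activity, read by MTT assay, with a stated time of 24 h; on this read-out lower numbers stand for stronger inhibition and higher numbers for weaker inhibition:
- compound 1 `CCn1c(C(=O)NCCCO)ccc1C(CC)(CC)c1ccc(OCS(=O)(=O)c2ccccc2)c(C)c1`: 11300 nM
- compound 2 `CCn1c(C(=O)N[C@@H](CO)CCO)ccc1C(CC)(CC)c1ccc(OCS(=O)(=O)c2ccccc2)c(C)c1`: 14100 nM
- compound 3 `CCn1c(C(=O)N[C@@H](C)C(=O)O)ccc1C(CC)(CC)c1ccc(OCS(=O)(=O)c2ccccc2)c(C)c1`: 16800 nM

Compound 3 stands level with both other compounds: a 1.5-fold higher number from compound 1 to compound 3 (0.17 log units; within the scatter) and a 1.2-fold higher number from compound 2 to compound 3 (0.08 log units; within the scatter). The next change gives compound 4 `CCn1c(C(=O)NC2(C(=O)O)CC2)ccc1C(CC)(CC)c1ccc(OCS(=O)(=O)c2ccccc2)c(C)c1`, with 1-carboxycyclopropyl in place of 1-carboxyethyl on an amide-type nitrogen. Within the data shown here, no measured step makes this exact change. The nearest evidence is those two steps, which replace the whole group on that nitrogen, together with a 1.2-fold higher number from compound 1 to compound 2 (0.10 log units; within the scatter). All stay within the scatter, so no step beyond the scatter is expected in this assay. The expected step is a 1.1-fold lower number from compound 3 to compound 4 (0.02 log units; within the scatter). The estimated value for compound 4 is 16000 nM, expected to fall from 8000 nM to 32000 nM.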

Compound 4, half-maximal inhibitory concentration: 26300 nM
Estimate against measurement, compound 4: 1.6-fold (0.22 log units) below, within the range that was stated.
By their numbers in this assay, from the lowest: compounds 1, 2, 3 and 4 (each within the scatter of the next, the first and the last beyond it).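

In this assay, 1-carboxycyclopropyl in place of 1-carboxyethyl on the amide-type nitrogen stays within the scatter, at a 1.6-fold higher number from compound 3 to compound 4 (0.19 log units; within the scatter), and the comparison with the diol-bearing group also stays within it, at a 1.9-fold higher number from compound 2 to compound 4 (0.27 log units; within the scatter). Among these compounds, the only step so far beyond the scatter at this nitrogen is modest, at a 2.3-fold higher number from compound 1 to compound 4 (0.37 log units; beyond the scatter), so 1-carboxycyclopropyl and 3-hydroxypropyl are the first two groups here that can be told apart. Nothing available explains this difference.

From the compounds shown here alone, whether a basic amine or a longer chain ending in a carboxylic acid on this nitrogen would take the number outside this narrow band remains open.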